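Cytotoxicity notes on quinazolinone anilines: methoxy versus hydroxy

The source may hold more compounds than are shown below. What is called first, only, known or untested is meant among the compounds shown, and "the series" means these compounds.

Compound 1 `COc1cccc(Nc2nc3cc(Cl)ccc3c(=O)[nH]2)c1` carries a methoxy group on the aniline ring. In an ADME assay on Vero cells (Chlorocebus sabaeus) for cytotoxicity, read by WST assay (on this read-out higher numbers stand for lower toxicity in this test and lower numbers for higher toxicity in this test), compound 1 gives > 25000 nM, which is a limit of the assay and not a number. Compound 2 `O=c1[nH]c(Nc2cccc(O)c2)nc2cc(Cl)ccc12` differs from compound 1 by hydrogen in place of methyl on an oxygen on an aromatic ring. In this assay compound 2 gives > 25000 nM, again a limit. The step that the two limits leave unreadable from compound 1 to compound 2 is therefore not readable in size; all that can be said rests on (the limit of > 25000 nM in this assay, at which 3 of the 3 values shown sit).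

Compound 3 `COc1cccc2nc(Nc3cc(Cl)cc(Cl)c3)[nH]c(=O)c12` belongs to a second core, with the methoxy group now on the bicyclic part; the difference between the two cores is not broken down here. In this assay compound 3 gives > 25000 nM, a limit as well.

Compound 4 `O=c1[nH]c(Nc2cc(Cl)cc(Cl)c2)nc2cccc(O)c12` is not yet measured. It differs from compound 3 by hydrogen in place of methyl on an oxygen on an aromatic ring, the same change as that from compound 1 to compound 2, at a place described in the same words. Because every value shown sits at the limit (the limit of > 25000 nM in this assay, at which 3 of the 3 values shown sit), the earlier step gives no size to carry over, and the expectation for compound 4 can only be that it too reaches the limit. The step that the limit leaves unreadable from compound 3 to compound 4 is thus estimated to be nil within what the assay can resolve. Compound 4 is expected to give 50000 nM in this assay, within an estimated range from 20000 nM to 150000 nM, most probably reported as a limit rather than a number.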

Compound 4, half-maximal cytotoxic concentration: > 25000 nM
Compound 4 ended at the assay's limit; the forecaster's own chance of this, stated with the estimate: 85%; the middle value lies beyond the limit too.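

No size can be read for the methoxy to hydroxy change from compound 3 to compound 4 in this assay, and the same holds from compound 1 to compound 2: the limit of > 25000 nM in this assay, at which 4 of the 4 values shown sit.

The compounds shown leave open whether methoxy and hydroxy differ at all in this assay, and what number any of these four compounds would give past the limit.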